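A few compounds are considered here, and "the series" means these few. Any claim that something is new, unique, unknown or untested is made for them only; others in the source may bear on it.

In a functional assay on HT-29 cells (Homo sapiens) for cytotoxicity, read by MTT assay, with a stated time of 72 h (a higher number here means a weaker inhibitor, a lower number a stronger inhibitor), the three measured compounds gave the following: compound 1 `COc1ccc(/C=N/c2c(C)n(C)n(-c3ccccc3)c2=O)cc1OC` gives 603000000 nM; compound 2 `COc1ccccc1/C=N/c1c(C)n(C)n(-c2ccccc2)c1=O` gives 70800000 nM; compound 3 `Cc1c(/N=C/c2ccccc2)c(=O)n(-c2ccccc2)n1C` gives 851000000 nM.

Compound 2 differs from compound 3 by methoxy in place of hydrogen on an aromatic carbon, and this single change produced a 12-fold lower number from compound 3 to compound 2 (1.08 log units; beyond the scatter). The difference between the cores of compound 1 and compound 3 is not broken down here; their two values lie within the usual scatter of each other.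

Compound 4 `COc1cc(/C=N/c2c(C)n(C)n(-c3ccccc3)c2=O)cc(OC)c1OC` differs from compound 1 by methoxy in place of hydrogen on an aromatic carbon. Among the measured compounds shown here, this is the same kind of change as the one from compound 3 to compound 2, but not the same: in compound 2 the methoxy enters ortho to a large group, whereas in compound 4 it enters ortho to a methoxy group, meta to a large group and meta to a methoxy group. Since compound 1 already carries two methoxy groups yet sits at 603000000 nM, the third methoxy is expected to give only a 1.3-fold lower number from compound 1 to compound 4 (0.13 log units; within the scatter). Compound 4 is therefore estimated at 450000000 nM, with a likely range from 150000000 nM to 1400000000 nM.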

Compound 4, half-maximal inhibitory concentration: 275000000 nM
The estimate for compound 4 lay 1.6-fold (0.21 log units) above the measured number, within the range that was stated.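

In this assay, the added methoxy gave a 2.2-fold lower number from compound 1 to compound 4 (0.34 log units; beyond the scatter), a modest step in the same direction as the earlier one. Methoxy in place of hydrogen on an aromatic carbon therefore lowered the number on both cores, but the size of the step did not carry from one core to the other: the same change on two cores in this assay, a 12-fold lower number (1.08 log units; beyond the scatter) from compound 3 to compound 2 and a 2.2-fold lower number (0.34 log units; beyond the scatter) from compound 1 to compound 4, 5.5-fold (0.74 log units) apart, beyond the scatter of two such steps. This does not show what sets the size of the step, as the methoxy enters a different place in each case and the starting compounds also differ in their other methoxy groups, and two steps are too few to give a rule for the series.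

The compounds shown carry only hydrogen or methoxy on this aromatic ring, which leaves open whether a hydroxyl group, a fluorine atom or an amine would follow either step. Going by these compounds, it also remains open whether a longer chain, such as ethoxy in place of methoxy, would give a step of similar size on either core.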